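From Octyl to Cycloheptyl on the Amide Nitrogen

The source may hold more compounds than are shown below. What is called first, only, known or untested is meant among the compounds shown, and "the series" means these compounds.

Within the data shown here, compound 1 `CCCCCCCCNC(=O)[C@H]1OC(n2cnc3c(N)ncnc32)[C@H](O)[C@@H]1O` gives the lower of the two numbers so far in an assay on cell membranes for binding affinity to 2-oxoglutarate receptor 1 (Rattus norvegicus), read by radioligand binding (a lower number here means a stronger inhibitor, a higher number a weaker inhibitor), where compound 1 gives 21 nM. Its only measured companion, compound 2 `CCCCCCCCCCCNC(=O)[C@H]1OC(n2cnc3c(N)ncnc32)[C@H](O)[C@@H]1O`, gives 123 nM in this assay, and the step of a 5.9-fold higher number from compound 1 to compound 2 (0.77 log units; beyond the scatter) shows that the longer chain comes with a higher number. Compound 3 `Nc1ncnc2c1ncn2C1O[C@H](C(=O)NC2CCCCCC2)[C@@H](O)[C@H]1O` differs from compound 1 in one place: cycloheptyl in place of octyl on an amide-type nitrogen. The octyl leaves and a cycloheptyl, one seven-membered non-aromatic ring of carbon only, enters on the amide-type nitrogen whose other neighbour is the carbonyl carbon. Among the measured compounds shown here, no measured step bears directly on this exchange of a chain for a ring; the only known step, from compound 1 to compound 2, concerns chain length and was modest. A change in this assay no larger than that, and possibly within the scatter, is therefore expected, leaning if anywhere toward a higher number. Compound 3 is expected at 40 nM, within 10 nM to 160 nM. The expected step is a 1.9-fold higher number from compound 1 to compound 3 (0.28 log units; within the scatter).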

Compound 3, inhibition constant: 22 nM
Beside the measured number, compound 3's estimate is 1.8-fold (0.26 log units) above it, within the range that was stated.
By their numbers in this assay, from the lowest: compounds 1 and 3 (each within the scatter of the next); then compound 2.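

In this assay, the step of a 1.0-fold higher number from compound 1 to compound 3 (0.02 log units; within the scatter) shows that the two groups on the amide-type nitrogen read alike, although one is an open octyl chain and the other a cycloheptyl ring. The earlier step of a 5.9-fold higher number from compound 1 to compound 2 (0.77 log units; beyond the scatter) had shown only that this position responds to a longer chain; the new result adds that a seven-membered ring of carbon only can take the place of the octyl chain and give a number within the scatter of compound 1. Nothing in the data shown accounts for this likeness between chain and ring.

As far as these compounds go, it remains open whether a smaller ring such as cyclopentyl, or an aromatic ring such as phenyl, would read the same way at this nitrogen. Also unsettled is how a shorter chain such as butyl, or a chain ending in an amine or a carboxylic acid, would compare with the octyl group.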